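This account rests on a few compounds, and the source may have more. Where it says the series, first, only, none or still open, it means among the compounds named here.

Compound 2 `COc1ccc(C(=O)/C=C/c2cc(-c3cc(OC)c(OC)c(OC)c3)n[nH]2)cc1` stands lowest of the two numbers recorded so far in a functional assay on MDA-MB-468 cells (Homo sapiens) for cytotoxicity, read by sulforhodamine B assay, with a stated time of 48 h, tested at 10 uM; a lower number here means a stronger effect, a higher number a weaker effect of the compound at the concentration tested: compound 2 gives -92%, while compound 1 `COc1cc(-c2cc(/C=C/C(=O)c3ccc(N)cc3)[nH]n2)cc(OC)c1OC` gives -58%. Going by the values given here, the only measured step, a number 34 percentage points lower from compound 1 to compound 2 (beyond the scatter), is beyond the scatter and large, and it concerns the group on the ring attached to the carbonyl carbon. Compound 3 `COc1cc(-c2cc(/C=C/C(=O)c3ccc(F)c(F)c3)[nH]n2)cc(OC)c1OC` has not been measured. It differs from compound 2 in one place: 3,4-difluorophenyl in place of 4-methoxyphenyl on a carbonyl carbon. Among the compounds with values here, no measured step exchanges this ring for one of a different substitution pattern, so the step from compound 1 to compound 2 is only an indirect guide; it shows that a change on this ring alone can shift the read-out by a large amount. Compound 3 carries neither the methoxy of compound 2 nor the amino of compound 1, so a step back toward a weaker effect is possible, but a result within the scatter cannot be excluded. The estimate for compound 3 in this assay is -75%, with a range from -100% to -45%. For compound 3 this means an expected step of a number 17 percentage points higher from compound 2 to compound 3 (beyond the scatter).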

Compound 3, a percentage reported as activity, at one concentration (the size of the read-out at that concentration, not a potency): -2%
Beside the measured number, compound 3's estimate is 73 percentage points below it, and the stated range ends below it.
By their numbers in this assay, from the lowest: compound 2; then compound 1; then compound 3.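

In this assay the ring on the carbonyl carbon turns out to do more than adjust the read-out: 3,4-difluorophenyl in place of 4-methoxyphenyl gives a number 90 percentage points higher from compound 2 to compound 3 (beyond the scatter) and takes the number close to zero. The same ring in place of 4-aminophenyl gives a number 56 percentage points higher from compound 1 to compound 3 (beyond the scatter) and so leaves compound 3 clearly apart from both earlier compounds, whereas the earlier comparison had shown only a difference between two rings that each carry one group and both give strongly negative numbers. The position therefore tolerates some exchanges far better than others, although no data shown give a reason for the loss with the 3,4-difluorophenyl ring.

The three compounds cannot separate the effect of having two fluorines from that of removing the methoxy or amino group, and they do not show whether a 4-fluorophenyl or an unsubstituted phenyl ring would stay close to compound 3 or to compound 2. Nor do they show how a 3,4-dimethoxyphenyl or 4-hydroxyphenyl ring would behave at this carbonyl carbon.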